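Sulfonyl methyl to trifluoromethyl on the benzylamine arm

The source may report more compounds than this note shows. Statements on the series, on what has been measured and on what is new or still open speak of the compounds shown alone.

Measured compounds:
compound 1, `CCc1nc(N)nc(N)c1-c1ccc(NCc2ccc(S(C)(=O)=O)cc2)cc1` — 7.4 nM
compound 2, `CCc1nc(N)nc(N)c1-c1ccc(NCc2cc(F)c(S(C)(=O)=O)c(F)c2)cc1` — 2.4 nM
compound 3, `CCc1nc(N)nc(N)c1-c1ccc(NCc2ccc(C(C)=O)cc2)cc1` — 57 nM

In an in vitro assay on CHOK cells for displacement of a labelled ligand from growth hormone secretagogue receptor type 1 (Homo sapiens) (on this read-out higher numbers stand for weaker inhibition and lower numbers for stronger inhibition), compound 2 stands lowest of the three numbers. Compound 1 sits nearest with a higher value, and compound 3 sits furthest. Within the data shown here, the one step between single-point neighbours is a 7.7-fold higher number from compound 1 to compound 3 (0.89 log units; beyond the scatter), where the sulfonyl group is exchanged for a carbonyl-bearing group; it shows that the sulfonyl end of the benzylamine arm is where the series is sensitive. Among the measured compounds shown here, no pair in the set varies only the carbon group on the sulfonyl sulfur.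

Compound 4, `CCc1nc(N)nc(N)c1-c1ccc(NCc2cc(F)c(S(=O)(=O)C(F)(F)F)c(F)c2)cc1`, is not yet measured. It differs from compound 2 by trifluoromethyl in place of methyl on a sulfonyl sulfur. For the measured compounds named here, no measured step bears directly on this change: the sulfonyl itself stays in place and the two ring fluorines of compound 2 remain. The step from compound 1 to compound 3 concerns the loss of the sulfonyl, not a change within it, and is therefore only a loose guide. In the absence of a direct comparison the expected step in this assay is small, a 1.3-fold higher number from compound 2 to compound 4 (0.10 log units; within the scatter), plausibly within the scatter. Compound 4 is therefore estimated at 3 nM, in the range 1 nM to 9 nM.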

Compound 4, half-maximal inhibitory concentration: 21 nM
Estimate against measurement, compound 4: 7.0-fold (0.85 log units) below, and the stated range ends below it.
By their numbers in this assay, from the lowest: compound 2; then compound 1; then compound 4; then compound 3.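

In this assay the sulfonyl and the ring fluorines stay in place, yet exchanging the carbon group on the sulfonyl sulfur gives an 8.8-fold higher number from compound 2 to compound 4 (0.94 log units; beyond the scatter) and so moves the number beyond the scatter. The earlier step, a 7.7-fold higher number from compound 1 to compound 3 (0.89 log units; beyond the scatter), replaced the whole methylsulfonyl group and could not show this: keeping the sulfonyl does not by itself hold the number, and the sensitivity at this end of the benzylamine arm reaches the group on sulfur. No measurement accompanies these numbers that would account for the step from methyl to trifluoromethyl, so it stands as an observation on these two compounds only.

Among these compounds, whether the same exchange gives a step of similar size without the ring fluorines stays open, as the only compounds differing in this one place are compound 2 and compound 4. Also open, from the compounds shown here alone, is how an ethyl, a cyclopropyl or an amine on the sulfonyl sulfur would read in this assay against methyl and trifluoromethyl, and so whether the number follows any trend across groups at this place.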